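The source may report more compounds than this note shows. Statements on the series, on what has been measured and on what is new or still open speak of the compounds shown alone.

For the measured compounds named here, compound 3 `Cc1cccc(Nc2nc(C)c(C(=O)/C=C/c3ccccc3)s2)c1` is the only member of this trio that gives an actual number in a functional assay on BGC-823 cells (Homo sapiens) for cytotoxicity, read by MTT assay; a higher number here means a weaker inhibitor, a lower number a stronger inhibitor: compound 3 gives 13600 nM. Compound 1 `COc1cccc(/C=C/C(=O)c2sc(Nc3cccc(C)c3)nc2C)c1` reaches only a limit in this assay, > 25000 nM. Compound 2 `Cc1nc(Nc2cccc(Cl)c2)sc1C(=O)/C=C/c1ccccc1` likewise stops at a limit in this assay, > 25000 nM. The steps of an at least 1.8-fold lower number from compound 1 to compound 3 (0.26 log units; that floor lies within the scatter) and an at least 1.8-fold lower number from compound 2 to compound 3 (0.26 log units; that floor lies within the scatter) are therefore floors rather than measured sizes, because the starting points are limits (the limit of > 25000 nM in this assay, at which 2 of the 3 values shown sit); both floors sit within the scatter of repeated measurement.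

Compound 4 `Cc1ccc(Nc2nc(C)c(C(=O)/C=C/c3ccccc3)s2)cc1` differs from compound 3 in one place: 4-methylphenyl in place of 3-methylphenyl on a nitrogen on an aromatic ring. The two measured steps also alter the substituent on the ring attached to that nitrogen, but each swaps one group for another rather than moving a methyl to a different carbon of the same ring, so neither speaks directly to this shift. Both steps stay within the scatter, so no step beyond the scatter is expected in this assay. The expected step is a 1.1-fold higher number from compound 3 to compound 4 (0.04 log units; within the scatter), which amounts to no change beyond the usual spread. Since two of the three compounds return only a limit in this assay, compound 4 may well do the same. Compound 4 is estimated at 15000 nM, with a range from 6000 nM to 40000 nM.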

Compound 4, half-maximal inhibitory concentration: > 25000 nM
Compound 4: a limit, no number (the forecaster's own chance of this, stated with the estimate: 40%); middle value at least 1.6-fold (0.22 log units) away from the limit.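

Moving the methyl group, so that 4-methylphenyl replaces 3-methylphenyl on the nitrogen, changes only the arrangement of the same atoms, unlike the earlier swaps of one group for another. In this assay, for the compounds shown here, this change gives an at least 1.8-fold higher number from compound 3 to compound 4 (0.26 log units; that floor lies within the scatter) and provides only a lower bound, so it cannot show that the position of the methyl matters, and compound 3 remains the only compound here with an actual number. The step from compound 2 to compound 4 cannot be read, and compound 4 adds to the compounds that end at a limit rather than a number, which restricts comparison across this small set: the limit of > 25000 nM in this assay, at which 3 of the 4 values shown sit.

As far as these compounds go, the true size of the step from the 3-methylphenyl to the 4-methylphenyl compound stays open, with only its floor known. Also open, from the compounds shown here alone, is whether an ethyl group, an amine or a carboxylic acid in place of the methyl on that ring would give a number in this assay and, if so, how it would compare with compound 3.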